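Camphor Sulfonyl Piperazines Tested as Chemokine Receptor Antagonists

The compounds below may be only part of what the source reports. "The series", "measured", "known", "first", "only" and "open" are said of these compounds alone.

Measured so far:
compound 1, `CC1CN(S(=O)(=O)C[C@]23CC[C@H](CC2=O)C3(C)C)CCN1c1ccc(C(F)(F)F)cn1`: 316 nM
compound 2, `CC1(C)[C@@H]2CC[C@@]1(CS(=O)(=O)N1CCN(c3ccc(Br)cn3)CC1)C(=O)C2`: 1580 nM

In a functional assay on CHO-K1 cells for antagonist activity at C-X-C chemokine receptor type 3 (Homo sapiens), read by FLIPR and calcium flux (on this read-out lower numbers stand for stronger inhibition and higher numbers for weaker inhibition), compound 2 gives 1580 nM, the highest of the two numbers. Compound 1 gives 316 nM, a lower number and thus stronger inhibition, with the gap beyond the scatter. Compound 3, `CC1(C)[C@@H]2CC[C@@]1(CS(=O)(=O)N1CCN(c3cc4ccccc4cn3)CC1)C(=O)C2`, keeps the core of compound 2 and differs in one place: isoquinolin-3-yl in place of 5-bromopyridin-2-yl on an amine nitrogen in a ring. Within the data shown here, no two measured compounds differ in one place, so this change has no precedent here. A modest step toward lower numbers is expected, a 2.0-fold lower number from compound 2 to compound 3 (0.30 log units; within the scatter). Compound 3 is expected to give 800 nM, within 250 nM to 2500 nM.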

Compound 3, half-maximal inhibitory concentration: 15800 nM
Compound 3: middle estimate off by 20-fold (1.30 log units), on the low side; the measured number lies above the stated range.
By their numbers in this assay, from the lowest: compound 1; then compound 2; then compound 3.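

Replacing 5-bromopyridin-2-yl with isoquinolin-3-yl on an amine nitrogen in a ring gives a 10-fold higher number from compound 2 to compound 3 (1.00 log units; beyond the scatter) in this assay, which means weaker inhibition. This position therefore does not accept every aromatic group, even though the incoming group has the same counts of hydrogen-bond donors and acceptors and the same net charge. No measurement at hand says why activity falls. Still open, as far as these compounds go, is whether a pyridine carrying chlorine or a nitrile in place of bromine would hold activity, and whether a quinoline would behave like isoquinolin-3-yl.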